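Pyrazole amides at metabotropic glutamate receptor 5

The source may report more compounds than this note shows. Statements on the series, on what has been measured and on what is new or still open speak of the compounds shown alone.

Measured so far:
- compound 1 `O=C(Nc1ccc(Br)cc1CN1C(=O)c2ccccc2C1=O)c1ccccn1`: 740 nM
- compound 2 `O=C(Nc1cc(-c2ccccc2)nn1-c1ccccc1)c1ccc(Cl)cc1`: 20 nM

In an assay on CHO cells with metabotropic glutamate receptor 5 (Homo sapiens) as the target (on this read-out higher numbers stand for an effect only at larger amounts of compound and lower numbers for an effect already at smaller amounts), compound 2 gives 20 nM and holds the lowest number of the two values in hand; compound 1 gives 740 nM in this assay, a gap that lies beyond the scatter. Compound 1 and compound 2 share no single point of difference, so their two values are all that can be said of the pair.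

Compound 3 `O=C(Nc1cc(-c2ccccc2)nn1-c1ccccc1)c1ccccn1` is not yet measured. It differs from compound 2 in one place: pyridin-2-yl in place of 4-chlorophenyl on a carbonyl carbon. Among the compounds with values here, nothing in the measured pair isolates this exchange on the core of compound 2, so no counted step can anchor the estimate.

The expectation is a modest move to a higher number, a step of a 3.0-fold higher number from compound 2 to compound 3 (0.48 log units; beyond the scatter), most likely beyond the scatter but not by much. Compound 3 is therefore estimated at 60 nM, with a range from 15 nM to 300 nM in this assay.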

Compound 3, half-maximal effective concentration: 290 nM
The estimate for compound 3 lay 4.8-fold (0.68 log units) below the measured number; measured number inside the range.
By their numbers in this assay, from the lowest: compound 2; then compound 3; then compound 1.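

In this assay, within the data shown here, the group on the carbonyl carbon of the core of compound 2 matters to the read-out: pyridin-2-yl in place of 4-chlorophenyl gives a 15-fold higher number from compound 2 to compound 3 (1.16 log units; beyond the scatter) and is the first exchange that can be read at a single place. Of the two groups, 4-chlorophenyl holds the lower number, so the ring with one hetero atom and one hydrogen-bond acceptor does not stand in for the carbon-only ring on this core. No measurement at hand explains the size of this step.

On these data alone, it remains open whether the step follows the entering ring nitrogen or the leaving chlorine; plain phenyl on the same carbonyl carbon would separate the two. Also open, as far as these compounds go, is how this position responds to an amine or a carboxylic acid on the ring.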